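Extending the Amide Nitrogen of Compound 1

The source may report more compounds than this note shows. Statements on the series, on what has been measured and on what is new or still open speak of the compounds shown alone.

Measured so far:
compound 1, `NC(=O)/C=C/c1ccncc1-c1ccc2ccccc2c1` — 102%
compound 2, `CCOC(=O)/C=C/c1ccncc1-c1ccc2c(ccn2C)c1` — 100%

Both compounds were tested in an assay on a protein complex for inhibition of CDK8/Cyclin C (Homo sapiens), with a stated time of 1 h, tested at 10 uM; a higher number here means more inhibition at the concentration tested (going by the name of the read-out), a lower number less inhibition. Compound 1 shows 102%, the higher of the two numbers, but compound 2 with 100% lies within the usual scatter of such measurements, so the two cannot be told apart and neither can be called the stronger.

Compound 3, `CC(C)[C@@H](NC(=O)/C=C/c1ccncc1-c1ccc2ccccc2c1)C(=O)O`, has not yet been measured. It differs from compound 1 in one place: 1-carboxy-2-methylpropyl in place of hydrogen on an amide-type nitrogen. Among the compounds with values here, no pair of measured compounds differs in a single place, so there is no measured step to lean on; the size of this change can only be expected, not read off. Since both measured numbers sit at the upper end of the percentage scale, the more likely direction is downward, by a moderate amount. Compound 3 is therefore expected to give 80%, within a range from 40% to 102%. This estimate means an expected step of a number 22 percentage points lower from compound 1 to compound 3 (beyond the scatter).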

Compound 3, a percentage reported as inhibition, at one concentration (the size of the read-out at that concentration, not a potency): 77%
The estimate for compound 3 lay 3 percentage points above the measured number; low and high end bracket the measured number.
By their numbers in this assay, from the lowest: compound 3; then compounds 2 and 1 (each within the scatter of the next).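

In this assay, the amide nitrogen of compound 1 still allows substantial inhibition after a much larger group is attached: placing 1-carboxy-2-methylpropyl there in place of hydrogen gives a number 25 percentage points lower from compound 1 to compound 3 (beyond the scatter) at this single concentration. Within the data shown here, this is the first measured change at this position, and it shows that the position is not indifferent to substitution, although compound 3 still reaches 77% in this assay. Nothing measured here gives a reason for the drop.

Going by these compounds, it remains open whether the loss follows the carboxylic acid, the branched carbon chain or the defined stereocentre of the new group. A plain methyl group or a short chain ending in an amine on the same nitrogen would test how much of the step depends on the carboxylic acid.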